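Adding a Third Fluorine to an Aryl Ether

The source may report more compounds than this note shows. Statements on the series, on what has been measured and on what is new or still open speak of the compounds shown alone.

Compound 1 `Cc1cc(COc2ccccc2)nc(-c2ccccn2)n1`: 2.7
Compound 2 `Cc1cc(COc2cccc(F)c2)nc(-c2ccccn2)n1`: 3.1
Compound 3 `Cc1cc(COc2ccc(F)cc2F)nc(-c2ccccn2)n1`: 3.1

Of the compounds shown here, three have been measured in a physicochemical assay for lipophilicity, at pH 7.4; a lower number here means a more polar compound, a higher number a more lipophilic compound. Compound 1 gives 2.7. Compound 2 differs from it by fluoro in place of hydrogen on an aromatic carbon, and in this assay the step is a number 0.40 log units higher from compound 1 to compound 2 (beyond the scatter). Compound 3 gives 3.1, level with compound 2 at the digits shown and together with it the highest of the three values; how compound 3 differs from compound 1 is not broken down here.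

Compound 4, `Cc1cc(COc2c(F)cc(F)cc2F)nc(-c2ccccn2)n1`, has not yet been measured. It differs from compound 3 by fluoro in place of hydrogen on an aromatic carbon. This is the same kind of change as that between compound 1 and compound 2, but not the same one: in compound 2 the fluoro sits meta to a large group, whereas in compound 4 it sits ortho to a large group and meta to two fluoro groups. Set beside the earlier step, the expected step is a number 0.20 log units higher from compound 3 to compound 4 (within the scatter), somewhat smaller, resting on a number 0.40 log units higher from compound 1 to compound 2 (beyond the scatter) while compound 2 and compound 3 show no change at the digits shown. Compound 4 is therefore expected at about 3.3, within a range from 3 to 3.7.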

Compound 4, distribution coefficient: 3.2
The estimate for compound 4 lay 0.10 log units above the measured number, within the range that was stated.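

In this assay, the new step is a number 0.10 log units higher from compound 3 to compound 4 (within the scatter), while the earlier step of the same kind is a number 0.40 log units higher from compound 1 to compound 2 (beyond the scatter). Fluoro in place of hydrogen on an aromatic carbon therefore gave a step beyond the scatter in only one of the two pairs, and in the new pair it sits ortho to a large group and meta to two fluoro groups. Both pairs keep the shared core, so they show that the step need not repeat at its full size from one placement to another, but they do not show how it would carry to a different core, and nothing measured here accounts for the difference between the two steps.

The compounds shown leave open whether a chloro group, a methoxy group or an amine in place of that fluoro would give a step of either size in this assay. Going by these compounds, it is also open whether the fluoro step would hold if a carboxylic acid or a longer chain stood in place of the methyl group on the shared core.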